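The compounds below may be only part of what the source reports. "The series", "measured", "known", "first", "only" and "open" are said of these compounds alone.

Measured in a functional assay on GLC82 cells (Homo sapiens) for cytotoxicity, read by MTT assay, with a stated time of 72 h; on this read-out lower numbers stand for stronger inhibition and higher numbers for weaker inhibition:
- compound 1 `COc1cc2ncnc(NNC(=S)NC(=O)c3ccccc3Cl)c2cc1OC`: 10000 nM
- compound 2 `COc1cc2ncnc(NNC(=S)NC(=O)c3ccc(C)cc3)c2cc1OC`: 29900 nM

Compound 2 stands at the highest of the two numbers in this assay; its nearest neighbour is compound 1, the step being a 3.0-fold higher number from compound 1 to compound 2 (0.48 log units; beyond the scatter). Compound 3 `COc1cc2ncnc(NNC(=S)NC(=O)c3ccccc3C)c2cc1OC` differs from compound 2 by 2-methylphenyl in place of 4-methylphenyl on a carbonyl carbon. Among the measured compounds shown here, no measured pair shows exactly this change. For the measured compounds named here, the only step that bears on it is a 3.0-fold higher number from compound 1 to compound 2 (0.48 log units; beyond the scatter), where a 2-chlorophenyl on the carbonyl carbon gave the lower number and a 4-methylphenyl the higher one; compound 3 returns to a 2-substituted ring, though with methyl rather than chlorine. A step of about that size is therefore expected, toward a lower number, with wide uncertainty. For compound 3 the expected value in this assay is 14000 nM, range 5000 nM to 40000 nM, an estimated step of a 2.1-fold lower number from compound 2 to compound 3 (0.33 log units; beyond the scatter).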

Compound 3, half-maximal inhibitory concentration: 21500 nM
Compound 3: middle estimate off by 1.5-fold (0.19 log units), on the low side; the measured number falls inside the stated range.
By their numbers in this assay, from the lowest: compound 1; then compounds 3 and 2 (each within the scatter of the next).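

In this assay the change from 4-methylphenyl to 2-methylphenyl on the carbonyl carbon gives a 1.4-fold lower number from compound 2 to compound 3 (0.14 log units; within the scatter) and so leaves no readable effect of moving the methyl, which means a 2-substituted ring alone does not bring the number down to that of compound 1. Methyl in place of chloro on the aromatic carbon gives a 2.2-fold higher number from compound 1 to compound 3 (0.33 log units; beyond the scatter) with the ring position held constant, so the lower number in this pair goes with chloro rather than with the position. Nothing measured here offers an explanation for this difference.

Still open, going by these compounds, is whether 4-chlorophenyl would stand apart from 4-methylphenyl as 2-chlorophenyl does from 2-methylphenyl. Also open, on these data alone, is how 2-methoxyphenyl or 2-aminophenyl on the same carbonyl carbon would read.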